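A few compounds are considered here, and "the series" means these few. Any claim that something is new, unique, unknown or untested is made for them only; others in the source may bear on it.

Compound 1, with the structure `CCC1C(=O)N(C)c2cnc(-n3ccc4cc(C(=O)NC)ccc43)nc2N1c1ccn(C)n1`, gives 13200 nM in a functional assay on Huh-7 cells (Homo sapiens) for antiproliferative activity, read by CCK-8 assay, with a stated time of 72 h; on this read-out lower numbers stand for stronger inhibition of growth and higher numbers for weaker inhibition of growth. Of the two compounds measured here it stands with the higher number, the weaker inhibition of growth. Among the measured compounds shown here, the only other measured compound, compound 2 with the structure `CC[C@@H]1C(=O)N(C)c2cnc(-n3ccc4cc(C(=O)NC(C)C)ccc43)nc2N1C1CCCC1`, gives 1660 nM in this assay; the two compounds differ in more than one place, so the gap between their numbers cannot be tied to any single change.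

The unmeasured compound 3 has the structure `CCC1C(=O)N(C)c2cnc(-n3ccc4cc(C(N)=O)ccc43)nc2N1c1ccn(C)n1`. It differs from compound 1 in one place: hydrogen in place of methyl on an amide-type nitrogen. The methylcarbamoyl group of compound 1 becomes a carbamoyl group in compound 3, the rest of the shared core being the same.

For the measured compounds named here, no measured pair in this set shows this kind of change, so there is nothing here to set its size. The change is small, and the expectation is that the step from compound 1 to compound 3 will stay within the usual scatter, or at most reach a modest weakening: a 1.2-fold higher number from compound 1 to compound 3 (0.08 log units; within the scatter). For compound 3 the estimated value in this assay is 16000 nM, with a range from 5000 nM to 45000 nM.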

Compound 3, concentration for 50% growth inhibition: "not active" (no number reported)
The entry for compound 3 holds no number, and the estimate cannot be compared.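

In this assay, among the compounds shown here, compound 3 is recorded as "not active" with no number, so no step from compound 1 to compound 3 can be read. The compounds shown leave open how far the change from methylcarbamoyl to carbamoyl moves growth inhibition in numerical terms. Nothing available here bears on this result.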